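Compound 3 to compound 4: 3-chlorophenyl for 4-hydroxyphenyl

The compounds below may be only part of what the source reports. "The series", "measured", "known", "first", "only" and "open" are said of these compounds alone.

In a functional assay on SiHa cells (Homo sapiens) for inhibition, read by sulforhodamine B assay (on this read-out higher numbers stand for weaker inhibition of growth and lower numbers for stronger inhibition of growth), compound 1 (`Oc1ccc(-c2ccc(-c3ccc(-c4nc5ccccc5[nH]4)cc3)cc2)cc1`) gives 33300 nM while compound 2 (`Clc1cccc(-c2ccc(-c3ccc(-c4nc5ccccc5[nH]4)cc3)cc2)c1`) gives 100000 nM and compound 3 (`Oc1ccc(-c2ccc(-c3ccc(-c4nc5c(O)cccc5[nH]4)cc3)cc2)cc1`) gives 2410 nM as the lowest of the three numbers, with its gaps to both others beyond the scatter. Compound 4 (`Oc1cccc2[nH]c(-c3ccc(-c4ccc(-c5cccc(Cl)c5)cc4)cc3)nc12`) is not yet measured. It differs from compound 3 by 3-chlorophenyl in place of 4-hydroxyphenyl on an aromatic carbon, para to a large group (3-chlorophenyl in place of 4-hydroxyphenyl on an aromatic carbon). The same exchange has been measured once, without the extra hydroxy (a 3.0-fold higher number from compound 1 to compound 2 (0.48 log units; beyond the scatter)), and that step is modest but beyond the scatter. The large step from hydroxy in place of hydrogen (a 14-fold lower number from compound 1 to compound 3 (1.14 log units; beyond the scatter)) concerns a different place, and that hydroxy stays in compound 4. Going by the values given here, only one pair shows the exchange, so its transfer to the hydroxy-bearing compounds is untested. A similar modest step toward a higher number is therefore expected (a 3.0-fold higher number from compound 3 to compound 4 (0.48 log units; beyond the scatter)) for this exchange. For compound 4 the estimated value is 7200 nM with an expected range from 2500 nM to 25000 nM as the working span.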

Compound 4, concentration for 50% growth inhibition: 8400 nM
Compound 4: middle estimate off by 1.2-fold (0.07 log units), on the low side; measured number inside the range.
By their numbers in this assay, from the lowest: compound 3; then compound 4; then compound 1; then compound 2.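

In this assay, 3-chlorophenyl in place of 4-hydroxyphenyl now reads on a second core, the one that keeps the added hydroxy, with a 3.5-fold higher number from compound 3 to compound 4 (0.54 log units; beyond the scatter), and the step keeps its size there: the same change on two cores in this assay, a 3.0-fold higher number (0.48 log units; beyond the scatter) from compound 1 to compound 2 and a 3.5-fold higher number (0.54 log units; beyond the scatter) from compound 3 to compound 4, 1.2-fold (0.06 log units) apart, within the scatter of two such steps. Hydroxy in place of hydrogen also now reads in a second setting, with a 12-fold lower number from compound 2 to compound 4 (1.08 log units; beyond the scatter), and it keeps its size with 3-chlorophenyl in place: the same change on two cores in this assay, a 14-fold lower number (1.14 log units; beyond the scatter) from compound 1 to compound 3 and a 12-fold lower number (1.08 log units; beyond the scatter) from compound 2 to compound 4, 1.2-fold (0.06 log units) apart, within the scatter of two such steps. Within these four compounds the two changes therefore behave as independent of each other, and none of the four goes against this.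

The ring exchange removes a hydroxy and brings in a chlorine at once, so the share of each in the step remains unresolved. From the compounds shown here alone, whether an amine or a methoxy could replace either hydroxy and keep these numbers also remains open.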